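Hydroxy at the chain end of the ethoxyethyl side chain

The source may report more compounds than this note shows. Statements on the series, on what has been measured and on what is new or still open speak of the compounds shown alone.

Compound 1 `CCOCCn1c(N2CCN(C)CC2)nc2ccccc21` gives the lowest number of the three in a functional assay on ileum for inhibition of histamine H1 receptor (Cavia porcellus) (on this read-out higher numbers stand for weaker inhibition and lower numbers for stronger inhibition), namely 10 nM. Compound 3 `C#CCOCCn1c(N2CCN(C)CC2)nc2ccccc21` gives 12 nM in this assay, and the step of a 1.2-fold higher number from compound 1 to compound 3 (0.08 log units; within the scatter) shows that exchanging the end of the oxygen-bearing chain costs nothing. Compound 2 `CCCC(C)n1c(N2CCN(C)CC2)nc2ccccc21`, with 1400 nM, marks the other extreme: the step of a 140-fold higher number from compound 1 to compound 2 (2.15 log units; beyond the scatter) follows once the oxygen-bearing chain itself is replaced. Compound 4 `CN1CCN(c2nc3ccccc3n2CCOCCO)CC1` keeps that chain and differs from compound 1 only by hydroxy in place of hydrogen on a saturated chain carbon, two bonds along the chain from an oxygen on a saturated carbon. Since the oxygen chain is retained and its end tolerated change in compound 3 a 1.2-fold higher number from compound 1 to compound 3 (0.08 log units; within the scatter), the step expected is a 1.5-fold higher number from compound 1 to compound 4 (0.18 log units; within the scatter), near the scatter. Compound 4 is therefore estimated at 15 nM, between 5 nM and 50 nM.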

Compound 4, half-maximal inhibitory concentration: 42 nM
Estimate against measurement, compound 4: 2.8-fold (0.45 log units) below, within the range that was stated.
By their numbers in this assay, from the lowest: compounds 1 and 3 (each within the scatter of the next); then compound 4; then compound 2.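

In this assay the chain end does not tolerate every change: hydroxy in place of hydrogen gives a 4.2-fold higher number from compound 1 to compound 4 (0.62 log units; beyond the scatter) and hydroxymethyl in place of ethynyl gives a 3.5-fold higher number from compound 3 to compound 4 (0.54 log units; beyond the scatter) even though the ethynyl end of compound 3 stayed within the scatter of compound 1. Replacing 1-methylbutyl with 2-(2-hydroxyethoxy)ethyl still gives a 33-fold lower number from compound 2 to compound 4 (1.52 log units; beyond the scatter) so the oxygen-bearing chain keeps most of its advantage with hydroxy at its end. No measurement at hand accounts for the step at this chain end. As far as these compounds go, whether an amine or a carboxylic acid at the chain end would behave like hydroxy remains open. From the compounds shown here alone, a longer chain carrying the same hydroxy also remains open.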